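Adding a 4-Chlorophenyl Group to a Thiourea Amide

A few compounds are considered here, and "the series" means these few. Any claim that something is new, unique, unknown or untested is made for them only; others in the source may bear on it.

Compound 1: `N#C/C(=C\N1CCN(C(=O)c2ccco2)C1=S)C(N)=O` — 43600 nM
Compound 2: `COc1cc(C(=O)N2CCN(C=O)C2=S)cc(OC)c1OC` — 24000 nM
Compound 3: `O=CN1CCN(C(=O)c2ccco2)C1=S` — 16800 nM

In a functional assay on OVCAR-8 cells (Homo sapiens) for inhibition, read by sulforhodamine B assay, with a stated time of 48 h (a lower number here means a stronger inhibitor of growth, a higher number a weaker inhibitor of growth), compound 1 gives 43600 nM, the highest of the three numbers. Compound 3 sits lower by a gap beyond the usual scatter, while compound 2 and compound 1 lie within the scatter of each other. From compound 1 the path leads to compound 4, `N#C/C(=C\N1CCN(C(=O)c2ccco2)C1=S)C(=O)Nc1ccc(Cl)cc1`, through one change: 4-chlorophenyl in place of hydrogen on an amide-type nitrogen. Among the compounds with values here, no two measured compounds differ in just this way, so nothing measured here shows what this change does. The expectation for the step from compound 1 to compound 4 in this assay is therefore a modest lowering, with wide uncertainty, namely a 2.2-fold lower number from compound 1 to compound 4 (0.34 log units; beyond the scatter). For compound 4 the value is estimated at 20000 nM, most likely between 5000 nM and 80000 nM.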

Compound 4, concentration for 50% growth inhibition: 20600 nM
Compound 4: middle estimate off by 1.0-fold (0.01 log units), on the low side; low and high end bracket the measured number.
By their numbers in this assay, from the lowest: compounds 3, 4, 2 and 1 (each within the scatter of the next, the first and the last beyond it).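

The step, a 2.1-fold lower number from compound 1 to compound 4 (0.33 log units; beyond the scatter), in this assay shows that this amide-type nitrogen can carry a whole aromatic ring in place of its hydrogen and still inhibit growth, with a modest gain rather than a loss. Within the data shown here, it is the first measured sign of what a change at this position does. Nothing available here explains why the number falls.

Going by these compounds, whether a plain phenyl ring, a methyl group or a longer chain on the same nitrogen would give a similar step remains open. So does the part played by the chlorine in this step.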